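A few compounds are considered here, and "the series" means these few. Any claim that something is new, unique, unknown or untested is made for them only; others in the source may bear on it.

Three compounds have been measured in a physicochemical assay for lipophilicity, read by LC-MS, in phosphate buffer, measured as octanol-water partition, with a stated time of 30 min, at pH 7.4, tested at 200 mM; a lower number here means a more polar compound, a higher number a more lipophilic compound:

compound 1 `Cn1c(COc2cccc(C(=O)O)c2)nc2ccc(Oc3ccc4c(c3)CCC4)nc21`, 2.5;
compound 2 `Cn1c(COc2cccc(C(=O)O)c2)nc2cnc(Oc3ccc4c(c3)CCC4)cc21`, 1.6;
compound 3 `Cn1c(COc2cccc(C(=O)O)c2)nc2ccc(Oc3ccccn3)cc21`, 0.4.

Compound 3 stands lowest of the three numbers. Its nearest neighbour is compound 2, whose value lies higher by a gap beyond the usual scatter, and compound 1 lies further still, also beyond the scatter. No two of these compounds differ in only one place, so no single step between measured compounds can be read off; the three values simply mark where each compound sits.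

Compound 4 `Cc1ccc(Oc2ccc3nc(COc4cccc(C(=O)O)c4)n(C)c3c2)nc1C` has not yet been measured in this assay. It differs from compound 3 in one place: 5,6-dimethylpyridin-2-yl in place of pyridin-2-yl on an oxygen on an aromatic ring. The group that enters is the larger of the two, with the same donor and acceptor count as the one that leaves. For the measured compounds named here, with no measured pair to calibrate this change, the value in this assay is expected to rise by a moderate step, beyond the scatter; the estimated step is a number 0.90 log units higher from compound 3 to compound 4 (beyond the scatter). Compound 4 is therefore expected to give about 1.3, within a range from 0.8 to 1.8.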

Compound 4, distribution coefficient: 1.3
The estimate for compound 4 equals the measured number at the digits printed; the range from low to high includes it.
By their numbers in this assay, from the lowest: compound 3; then compounds 4 and 2 (each within the scatter of the next); then compound 1.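

In this assay, for the compounds shown here, the exchange of pyridin-2-yl for 5,6-dimethylpyridin-2-yl on an oxygen on an aromatic ring supplies the first change that can be read in a single place, a modest step that comes out as a number 0.90 log units higher from compound 3 to compound 4 (beyond the scatter) and so stands clear of repeat-measurement noise. The entering group has two more carbon atoms than the group that leaves, while the six-membered aromatic ring, its one hetero atom and the donor and acceptor counts stay the same, so this position does register a change confined to added carbon. Nothing available explains the size of this step or gives a measured cause for it.

On these data alone, how the step divides between the two methyl groups remains open, as does what 5-methylpyridin-2-yl or 6-methylpyridin-2-yl alone would give at this place. Also open, as far as these compounds go, are whether the same exchange gives a step of this size on the cores of the other compounds, and what a methoxy group or an amine on the pyridine ring would do to the number.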